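Compound 3 to compound 4: a 4-cyanophenyl swap

The source may report more compounds than this note shows. Statements on the series, on what has been measured and on what is new or still open speak of the compounds shown alone.

In a functional assay on SMMC-7721 cells (Homo sapiens) for cytotoxicity, read by MTT assay, with a stated time of 24 h (a higher number here means a weaker inhibitor, a lower number a stronger inhibitor), compound 3 (`CN1C/C(=C\c2cccnc2)C(=O)/C(=C/c2ccc(F)cc2Br)C1`) gives 20800 nM, within the scatter of compound 1 (`COc1cc(/C=C2\CN(C)C/C(=C\c3cccnc3)C2=O)cc(OC)c1`) at 17900 nM. Compound 2 (`CN1C/C(=C\c2cccnc2)C(=O)/C(=C/c2ccccc2F)C1`) gives 5420 nM, a lower number than either, and beyond the scatter of both.

The next change leads to compound 4 (`CN1C/C(=C\c2ccc(C#N)cc2)C(=O)/C(=C/c2cccnc2)C1`), and its difference from compound 3 is 4-cyanophenyl in place of 2-bromo-4-fluorophenyl on a double-bonded chain carbon bound to a double-bonded ring carbon. For the measured compounds named here, only one measured step bears on it: a 3.8-fold higher number from compound 2 to compound 3 (0.58 log units; beyond the scatter), a modest step in which 2-bromo-4-fluorophenyl replaced 2-fluorophenyl on the same double-bonded chain carbon. Going by the values given here, no measured compound carries 4-cyanophenyl, so the direction is uncertain. With 2-bromo-4-fluorophenyl leaving, a step in this assay of similar or smaller size towards a lower number is expected, given the modest size of a 3.8-fold higher number from compound 2 to compound 3 (0.58 log units; beyond the scatter). The estimated change is a 2.1-fold lower number from compound 3 to compound 4 (0.32 log units; beyond the scatter). For compound 4 the expected value is 10000 nM, with an estimated range of 3500 nM to 28000 nM.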

Compound 4, half-maximal inhibitory concentration: 13600 nM
Compound 4: middle estimate off by 1.4-fold (0.13 log units), on the low side; measured number inside the range.
By their numbers in this assay, from the lowest: compound 2; then compounds 4, 1 and 3 (each within the scatter of the next).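

On a double-bonded chain carbon bound to a double-bonded ring carbon, this assay does not separate 4-cyanophenyl from 2-bromo-4-fluorophenyl, with a 1.5-fold lower number from compound 3 to compound 4 (0.18 log units; within the scatter) as the step between them. The step of a 2.5-fold higher number from compound 2 to compound 4 (0.40 log units; beyond the scatter) shows a second replacement of 2-fluorophenyl, after a 3.8-fold higher number from compound 2 to compound 3 (0.58 log units; beyond the scatter), also giving a higher number beyond the scatter, and since 4-cyanophenyl carries neither bromine nor fluorine, neither atom is needed for that rise among these compounds. No measurement on hand gives a reason for these steps.

Open, as far as these compounds go, is whether a phenyl ring bearing an amine or a carboxylic acid in place of the nitrile, at this same place, would stay near compound 3 or approach compound 2 at 5420 nM in this read-out. Also open, from the compounds shown here alone, is whether these steps hold in any other cell line.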